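The compounds below may be only part of what the source reports. "The series", "measured", "known", "first", "only" and "open" are said of these compounds alone.

Among the measured compounds shown here, compound 2 `Nc1cc(N)c2nc(-c3ccccc3)c(NCc3ccc(Cl)c(Cl)c3)nc2c1` is the only compound here with a measured number: in a functional assay on A549 cells (Homo sapiens) for inhibition, read by sulforhodamine B assay, with a stated time of 48 h (on this read-out lower numbers stand for higher toxicity in this test and higher numbers for lower toxicity in this test), compound 2 gives 69200 nM. Compound 1 `CCOC(=O)[C@H](CCC(=O)O)NC(=O)c1ccc(CNc2nc3cc(N)cc(N)c3nc2-c2ccccc2)cc1` stands at a limit of this test rather than at a number: in this assay compound 1 gives < 100000 nM. That limit appears as the limit of < 100000 nM in this assay, at which 1 of the 2 values shown sits. No step between two measured compounds is shown, so nothing measured tells how a change of this kind plays out. Compound 3 `COc1ccc(CNc2nc3cc(N)cc(N)c3nc2-c2ccccc2)cc1` differs from compound 2 in one place: 4-methoxyphenyl in place of 3,4-dichlorophenyl on a saturated chain carbon bound to a nitrogen on an aromatic ring. For the measured compounds named here, with no measured step to lean on, the expected step is a 1.2-fold higher number from compound 2 to compound 3 (0.06 log units; within the scatter), which would sit within the usual scatter rather than beyond it in either direction. Compound 3 is therefore expected to give about 80000 nM in this assay, with a likely range from 30000 nM to 200000 nM, and a fair chance that only a limit is reported.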

Compound 3, concentration lethal to 50% of the cells: < 100000 nM
Compound 3: no number, only a limit; the forecaster's own chance of this, stated with the estimate: 40%; the middle value is on the limit's open side.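

Among the compounds shown here, compound 3 gives < 100000 nM in this assay; this is a limit and not a number, so no step between compound 2 and compound 3 can be read. Going by these compounds, whether 4-methoxyphenyl in place of 3,4-dichlorophenyl changes the lethal concentration at all, and in which direction, stays open.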